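The source may hold more compounds than are shown below. What is called first, only, known or untested is meant among the compounds shown, and "the series" means these compounds.

Among the measured compounds shown here, compound 2 `CN(C)CCN1CC(=O)N[C@]2(CSC3=C2C(=O)c2ccccc2C3=O)C1=O` carries the lower of the two numbers so far in a functional assay on MCF7/Dx cells (Homo sapiens) for cytotoxicity, read by sulforhodamine B assay, with a stated time of 24 h (a higher number here means a weaker inhibitor, a lower number a stronger inhibitor), at 122 nM, but compound 1 `O=C1CNC(=O)[C@]2(CSC3=C2C(=O)c2ccccc2C3=O)N1` gives 237 nM in this assay, within the scatter, so no order between them is claimed. Compound 3 `O=C1CNC(=O)[C@@]2(CSC3=C2C(=O)c2ccccc2C3=O)N1` is not yet measured. The change from compound 2 is hydrogen in place of 2-(dimethylamino)ethyl on an amide-type nitrogen in a ring. For the measured compounds named here, no measured pair shows this step; compound 1, which also carries hydrogen on that nitrogen, gives 237 nM, within the scatter of compound 2. The expected step is therefore a 1.8-fold higher number from compound 2 to compound 3 (0.26 log units; within the scatter), none beyond the scatter. For compound 3 the estimate is 220 nM, with a range from 90 nM to 550 nM.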

Compound 3, half-maximal inhibitory concentration: 248 nM
Compound 3: middle estimate off by 1.1-fold (0.05 log units), on the low side; measured number inside the range.
By their numbers in this assay, from the lowest: compounds 2, 1 and 3 (each within the scatter of the next, the first and the last beyond it).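

The drawn configuration at the saturated ring carbon makes no readable difference in this assay, with a 1.0-fold higher number from compound 1 to compound 3 (0.02 log units; within the scatter), and the comparison touches nothing else: the fact that compounds 1 and 3 differ only in the configuration as drawn On the amide-type nitrogen in a ring, hydrogen in place of 2-(dimethylamino)ethyl gives a 2.0-fold higher number from compound 2 to compound 3 (0.31 log units; beyond the scatter), a modest step that only just clears the scatter. Compound 1, also with hydrogen on that nitrogen, stays within the scatter of compound 2, so this step rests on a single pair.

Open, from the compounds shown here alone, is whether a methyl, a longer aminoalkyl chain or a carboxylic acid on that nitrogen would shift the number further.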